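The source may report more compounds than this note shows. Statements on the series, on what has been measured and on what is new or still open speak of the compounds shown alone.

In an ADME assay on the whole organism (Rattus norvegicus) for metabolic stability (on this read-out higher numbers stand for a longer-lived compound and lower numbers for a shorter-lived compound), compound 1 (`O=C(NCc1ccc(F)cc1)c1cnc(-c2ccccn2)nc1O`) gives 3.3 h. For the measured compounds named here, compound 2 (`CC(C)(NC(=O)c1cnc(-c2cscn2)nc1O)c1ccccc1`) gives 2.9 h, so the only two numbers available lie within the usual scatter of each other, and compound 2 stands level with compound 1. Going by the values given here, the two compounds differ in more than one place, so they offer no clean step to learn from.

Compound 3 (`CC(C)(NC(=O)c1cnc(-n2cccn2)nc1O)c1ccccc1`) keeps the rest of compound 2 and carries 1H-pyrazol-1-yl in place of 1,3-thiazol-4-yl on an aromatic carbon. Among the compounds with values here, no measured pair shows what this exchange does. No step beyond the scatter is therefore expected in this assay, and no direction is clearly favoured. The expectation rests on compound 2 at 2.9 h. The estimated change is a 1.1-fold lower number from compound 2 to compound 3 (0.05 log units; within the scatter). For compound 3 the estimated half-life is 2.6 h, with an expected range from 1.2 h to 5.6 h.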

Compound 3, half-life: 4.2 h
For compound 3 the middle estimate is 1.6-fold (0.21 log units) below the measured one, within the range that was stated.
By their numbers in this assay, from the lowest: compounds 2, 1 and 3 (each within the scatter of the next).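

In this assay, for the compounds shown here, the exchange of 1,3-thiazol-4-yl for 1H-pyrazol-1-yl on the aromatic carbon between two ring nitrogen atoms gives a 1.4-fold higher number from compound 2 to compound 3 (0.16 log units; within the scatter) and so provides the first clean step at this position. The two groups match in heavy atom count and are each one five-membered aromatic ring with 2 hetero atoms, yet one carries sulfur and the other an extra nitrogen, and this read-out does not separate them. No measurement shown here accounts for the size of this step.

From the compounds shown here alone, it remains open how a group of a different kind on this same aromatic carbon, such as an amine or a carboxylic acid, would read. Going by these compounds, it is also open whether this exchange would give a similar step with another amide side chain, such as the 4-fluorobenzyl group of compound 1.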